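Amide aryl variation on the shared flavonol core

The compounds below may be only part of what the source reports. "The series", "measured", "known", "first", "only" and "open" are said of these compounds alone.

Measured so far:
compound 1, `Cc1ccccc1C(=O)Nc1cccc(-c2oc3cc(-c4ccc(F)cc4)ccc3c(=O)c2O)c1`, 2280 nM in a functional assay on MCF7 cells (Homo sapiens) for antiproliferative activity, read by CCK-8 assay, with a stated time of 72 h; a higher number here means a weaker inhibitor, a lower number a stronger inhibitor
compound 2, `O=C(Nc1cccc(-c2oc3cc(-c4ccc(F)cc4)ccc3c(=O)c2O)c1)c1ccc(C(F)(F)F)cc1`, 32600 nM in this assay

For the measured compounds named here, compound 2 stands at the highest of the two numbers so far; the nearest is compound 1, and the one measured step, a 14-fold higher number from compound 1 to compound 2 (1.16 log units; beyond the scatter), is large and beyond the scatter. That step is the only one bearing on the next move, since both compounds differ only in the aryl group on the carbonyl carbon.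

Compound 3, `O=C(Nc1cccc(-c2oc3cc(-c4ccc(F)cc4)ccc3c(=O)c2O)c1)c1cccc(F)c1`, is still to be measured. The change from compound 2 is 3-fluorophenyl in place of 4-(trifluoromethyl)phenyl on a carbonyl carbon. The trifluoromethyl group leaves and a single fluorine enters at a different ring position. Going by the values given here, no measured pair tests a 3-fluorophenyl group directly, so the expectation rests on the measured step alone: the 4-(trifluoromethyl)phenyl group gave a markedly higher number than 2-methylphenyl, and compound 3 carries neither. A lower number than compound 2 is therefore expected for compound 3, estimated as a 5.0-fold lower number from compound 2 to compound 3 (0.70 log units; beyond the scatter), though how far back towards compound 1 it goes is uncertain. The estimate for compound 3 is 6500 nM, with a range from 2000 nM to 22000 nM.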

Compound 3, half-maximal inhibitory concentration: 5770 nM
For compound 3 the middle estimate is 1.1-fold (0.05 log units) above the measured one; measured number inside the range.
By their numbers in this assay, from the lowest: compound 1; then compound 3; then compound 2.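

Notes on the aryl group on the carbonyl carbon, whose other neighbour is the amide-type nitrogen: in this assay, 3-fluorophenyl in place of 4-(trifluoromethyl)phenyl gives a 5.6-fold lower number from compound 2 to compound 3 (0.75 log units; beyond the scatter) and so takes back much of the earlier loss. Against the 2-methylphenyl group, however, the same 3-fluorophenyl group gives a 2.5-fold higher number from compound 1 to compound 3 (0.40 log units; beyond the scatter) and does not restore the full level, which shows that this position grades the three aryl groups rather than separating one poor group from two equal ones. The swap from 4-(trifluoromethyl)phenyl changes both the substituent and its place on the ring, so the step cannot be assigned to either change alone, and nothing at hand accounts for the order of the three compounds.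

A 4-fluorophenyl or a 3-(trifluoromethyl)phenyl group on the same carbonyl carbon would separate the substituent from its ring position, and an unsubstituted phenyl group would give a plain reference for all three. As far as these compounds go, whether an aryl group carrying an amine or a carboxylic acid fits this series also remains open.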